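This account rests on a few compounds, and the source may have more. Where it says the series, first, only, none or still open, it means among the compounds named here.

Compound 1 `COc1ccc(C2=C(c3cc(OC)c(OC)c(OC)c3)C(=O)C(OC(C)=O)C2)cc1OC(C)C`: > 100 ug/mL
Compound 2 `C=CCOc1cc(C2=C(c3cc(OC)c(OC)c(OC)c3)C(=O)C(O)C2)ccc1OC`: > 100 ug/mL
Compound 3 `COC(=O)c1cc(C2=C(c3cc(OC)c(OC)c(OC)c3)C(=O)CC2O[SiH2]C(C)(C)C)ccc1OC`: > 100 ug/mL

All three compounds were tested in an ADME assay on HEp-2 cells (Homo sapiens) for cytotoxicity, read by MTT assay, with a stated time of 72 h (on this read-out higher numbers stand for weaker inhibition and lower numbers for stronger inhibition), and each result is a limit of the assay, not a number. Compound 1 stands at that limit, > 100 ug/mL. Compound 2 and compound 3 offer no number to rank it against, as the limit of > 100 ug/mL in this assay, at which 3 of the 3 values shown sit, shows. For the measured compounds named here, no pair of measured compounds differs in only one place, so no measured step gauges the size of a single change.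

Compound 4 `COc1ccc(C2=C(c3cc(OC)c(OC)c(OC)c3)C(=O)C(OC(C)=O)C2)cc1F` keeps the core of compound 1 and carries fluoro in place of isopropoxy on an aromatic carbon, ortho to a methoxy group: fluoro in place of isopropoxy on an aromatic carbon. In this assay, the expectation is for no step beyond the scatter, and a reported limit is the most likely outcome. Any real move would be expected toward stronger inhibition, since the measured compounds leave no room to see one toward weaker inhibition. The expected step is a number no higher from compound 1 to compound 4 (the limit leaves the size open). For compound 4 the estimated value is 100 ug/mL, with an expected range from 20 ug/mL to 200 ug/mL.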

Compound 4, half-maximal inhibitory concentration: < 1 ug/mL
Compound 4: no number, only a limit (the forecaster's own chance of this, stated with the estimate: 65%); at least 100-fold (2.00 log units) between middle value and limit.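

In this assay, fluoro in place of isopropoxy gives an at least 100-fold lower number from compound 1 to compound 4 (2.00 log units; beyond the scatter). For the compounds shown here, this shows that a single change on this aromatic carbon, ortho to a methoxy group, can move the read-out across the whole span of the assay, which the earlier compounds, all resting at one limit, could not show. Compound 4 alone sits at the opposite limit: the limit of < 1 ug/mL in this assay, at which 1 of the 4 values shown sits.

As far as these compounds go, whether the step belongs to fluoro itself or to the loss of isopropoxy stays open, and a chloro or an ethoxy group at this carbon would separate the two. Also open, from the compounds shown here alone, is the true size of the step, as both of its ends are limits, and whether fluoro would do the same on the cores of compound 2 and compound 3.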